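Trading Hydroxymethyl for Methyl on a Shared Core

A few compounds are considered here, and "the series" means these few. Any claim that something is new, unique, unknown or untested is made for them only; others in the source may bear on it.

Compound 1 `CC(=O)O[C@@H]1C[C@@H](OC(C)=O)C(C)(C)/C=C/[C@H](C)[C@H](OC(C)=O)[C@@]2(O)C[C@H](C)[C@H](OC(=O)c3ccccc3)[C@@H]2/C=C/1CO` and compound 2 `CC(=O)O[C@@H]1[C@H](C)/C=C/C(C)(C)C(=O)C[C@@H](OC(=O)c2ccccc2)/C(CO)=C/[C@H]2[C@@H](OC(=O)c3ccccc3)[C@H](C)C[C@]12OC(C)=O` share a closely related core, and both were tested in a functional assay on HeLa cells (Homo sapiens) for cytotoxicity, read by MTT assay; a higher number here means a weaker inhibitor, a lower number a stronger inhibitor. In this assay compound 1 gives > 10000 nM, which is a limit of the assay rather than a number. Compound 2 gives > 10000 nM in this assay, again a limit and not a number. So compound 2 stands where every value shown so far sits, as the limit of > 10000 nM in this assay, at which 2 of the 2 values shown sit, records; nothing separates it from compound 1 on the numbers. Compound 3 `CC(=O)O[C@@H]1[C@H](C)/C=C/C(C)(C)C(=O)C[C@@H](OC(=O)c2ccccc2)/C(C)=C/[C@H]2[C@@H](OC(=O)c3ccccc3)[C@H](C)C[C@]12OC(C)=O` has not yet been measured, and it differs from compound 2 by hydrogen in place of hydroxy on a saturated chain carbon bound to a double-bonded ring carbon. Put briefly, hydroxymethyl becomes methyl. Going by the values given here, no measured step exists to lean on, and the change is small. In this assay the expected step is a step that the limit leaves unreadable from compound 2 to compound 3, none beyond the scatter. Compound 3 is expected to give about 15000 nM, between 4000 nM and 60000 nM, most likely again only as a limit.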

Compound 3, half-maximal inhibitory concentration: > 10000 nM
Compound 3: a limit, no number; the forecaster's own chance of this, stated with the estimate: 80%; the middle value does not contradict the limit.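

In this assay compound 3 gives > 10000 nM, which is a limit of the assay and not a number. Compound 2 also has only a limit, so no step can be read between compound 2 and compound 3. The compounds shown leave open whether hydroxymethyl and methyl differ at all in this assay.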